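The source may hold more compounds than are shown below. What is called first, only, known or untested is meant among the compounds shown, and "the series" means these compounds.

Compound 1 `C=CCc1ccccc1OCCCNC(C)C`, with 56 nM in an assay for inhibition of squalene synthase (Rattus norvegicus), using microsomes; on this read-out lower numbers stand for stronger inhibition and higher numbers for weaker inhibition.
Compound 2 `C=CCc1cc(OCCCC)ccc1OCCCNC(C)C`, with 0.6 nM in this assay.

Within the data shown here, compound 2 shows the lowest of the two numbers in this assay; its nearest neighbour is compound 1, and the single step of a 93-fold lower number from compound 1 to compound 2 (1.97 log units; beyond the scatter) is the only measured change available. That step was large, beyond the scatter, and was carried by butoxy in place of hydrogen on an aromatic carbon.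

Compound 3 `C=CCc1cc(CO/N=C/C)ccc1OCCCNC(C)C` is not yet measured. The change from compound 2 is a group of 5 heavy atoms (3 carbon, 1 nitrogen, 1 oxygen; no ring) in place of a group of 5 heavy atoms (4 carbon, 1 oxygen; no ring), on an aromatic carbon, meta to an allyl group. Among the measured compounds shown here, no measured step exactly covers this exchange; the only bearing step shows how much a group at that aromatic carbon can matter. Because a 93-fold lower number from compound 1 to compound 2 (1.97 log units; beyond the scatter) was so large, a group of equal size there is expected to keep much of the gain over compound 1, though not all of it, so the estimate for compound 3 is a moderate step of a 5.0-fold higher number from compound 2 to compound 3 (0.70 log units; beyond the scatter). Compound 3 is therefore expected to give about 3 nM, within the range 0.6 nM to 20 nM.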

Compound 3, half-maximal inhibitory concentration: 0.2 nM
Compound 3: the middle estimate sits 15-fold (1.18 log units) above what was measured; measured number below the stated range.
By their numbers in this assay, from the lowest: compound 3; then compound 2; then compound 1.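

In this assay, the gain at the aromatic carbon meta to an allyl group turns out not to depend on butoxy: the exchange gives a 3.0-fold lower number from compound 2 to compound 3 (0.48 log units; beyond the scatter), with the count held at 5 heavy atoms while nitrogen and a double bond outside aromatic rings enter the group. Set against hydrogen at the same carbon, the entering group gives a 280-fold lower number from compound 1 to compound 3 (2.45 log units; beyond the scatter), so two different unbranched-looking groups of equal heavy-atom count both give large gains there, and the step between them also lies beyond the scatter. Nothing available accounts for the lower number of compound 3.

What the compounds shown leave open is which part of the entering group carries the extra gain over butoxy, the nitrogen, the oxygen's placement or the double bond, since all of these change together in this single step. They also leave open how far this carbon accepts other kinds of group, such as a longer chain, an amine or a carboxylic acid, and whether the gain would keep growing or reverse.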